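A few compounds are considered here, and "the series" means these few. Any claim that something is new, unique, unknown or untested is made for them only; others in the source may bear on it.

Three chalcones have been measured in an ADME assay on A2780 cells (Homo sapiens) for inhibition, read by trypan blue exclusion, with a stated time of 72 h; a lower number here means a stronger inhibitor of growth, a higher number a weaker inhibitor of growth. Compound 1 `O=C(/C=C/c1ccccc1)c1ccccc1[N+](=O)[O-]` gives 5800 nM in this assay. Compound 2 `COc1cccc(C(=O)/C=C/c2ccccc2)c1` gives 8000 nM in this assay. Compound 3 `O=C(/C=C/c1ccc(C(F)(F)F)cc1)c1ccccc1` gives 14000 nM in this assay. Compound 2 sits between the other two numbers, and its gap to compound 1, the nearer of the two, and its gap to compound 3, the further of the two, both lie within the usual scatter of repeated measurements, so the three values cannot be told apart.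

Compound 4 `O=C(/C=C/c1ccccc1)c1cccc(C(F)(F)F)c1` has not yet been measured. It differs from compound 2 in one place: trifluoromethyl in place of methoxy on an aromatic carbon. Within the data shown here, the change swaps one group for another of the same kind of position on the same ring, and the measured compounds give no step between two otherwise identical structures from which to read its size. Compound 3 also carries trifluoromethyl, though on the other ring, and its number in this assay is 14000 nM. Compound 4 is therefore expected to land close to compound 2, with a step of a 1.3-fold higher number from compound 2 to compound 4 (0.10 log units; within the scatter) that stays within the scatter. The estimate for compound 4 in this assay is 10000 nM, with a range from 4000 nM to 25000 nM.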

Compound 4, concentration for 50% growth inhibition: > 20000 nM
Compound 4: a limit, no number (the forecaster's own chance of this, stated with the estimate: 5%); at least 2.0-fold (0.30 log units) between middle value and limit.
By their numbers in this assay, from the lowest: compounds 1, 2 and 3 (each within the scatter of the next, the first and the last beyond it). At a limit, above all of these: compound 4.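

In this assay compound 4 gives > 20000 nM, which is a limit of the assay and not a number. Trifluoromethyl in place of methoxy on an aromatic carbon, meta to a large group, gives the first step here that can be read between two otherwise identical structures, and that step is an at least 2.5-fold higher number from compound 2 to compound 4 (0.39 log units; beyond the scatter), so this change on this ring carbon weakens growth inhibition by more than the scatter, something the earlier compounds, which offered no such step, could not show. The size of the step has only a lower bound, and the true value of compound 4 cannot be read, as it rests on the ceiling of the measurement: the limit of > 20000 nM in this assay, at which 1 of the 4 values shown sits.

The compounds shown leave open whether the weaker inhibition follows from methoxy leaving or from trifluoromethyl entering, and whether any other replacement on this aromatic carbon would retain the level of compound 2. What a hydroxyl, an amine or a chlorine at this same place would give remains an open question, as does the effect of the same swap on the other ring of the shared core.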